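The source may report more compounds than this note shows. Statements on the series, on what has been measured and on what is new or still open speak of the compounds shown alone.

Values in a functional assay on MCF7 cells (Homo sapiens) for antiproliferative activity (on this read-out higher numbers stand for weaker inhibition and lower numbers for stronger inhibition), for the measured members of the series:

compound 1 `COc1cc(Cc2nc3c(N)nc(F)nc3n2CCOC(C)C)cc(OC)c1OC`: 15800 nM
compound 2 `CCCCCn1c(Cc2cc(OC)c(OC)c(OC)c2)nc2c(N)nc(F)nc21`: 36300 nM
compound 3 `CC#CCCn1c(Cc2cc(OC)c(OC)c(OC)c2)nc2c(N)nc(F)nc21`: 37200 nM

Compound 3 holds the highest number of the three. Its gap to compound 2 is within the scatter (a 1.0-fold higher number from compound 2 to compound 3 (0.01 log units; within the scatter)), so no order between those two can be claimed; its gap to compound 1 is beyond it (a 2.4-fold higher number from compound 1 to compound 3 (0.37 log units; beyond the scatter)).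

Compound 4 `C=CCCn1c(Cc2cc(OC)c(OC)c(OC)c2)nc2c(N)nc(F)nc21` is the next member. It differs from compound 3 by vinyl in place of prop-1-yn-1-yl on a saturated chain carbon, two bonds along the chain from an aromatic nitrogen. Going by the values given here, the steps that bear on this position are all exchanges of the chain on that same carbon: a 1.0-fold higher number from compound 2 to compound 3 (0.01 log units; within the scatter), which shows that swapping one three-carbon chain for another there left the number unchanged, and the modest 2.3-fold higher number from compound 1 to compound 2 (0.36 log units; beyond the scatter) and a 2.4-fold higher number from compound 1 to compound 3 (0.37 log units; beyond the scatter), which involve the only chain of the set that carries an oxygen. Going from one hydrocarbon chain to a shorter one is therefore expected to give no step beyond the scatter: a 1.1-fold lower number from compound 3 to compound 4 (0.03 log units; within the scatter). For compound 4 the estimate in this assay is 35000 nM, with a range from 15000 nM to 80000 nM.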

Compound 4, half-maximal inhibitory concentration: 33100 nM
For compound 4 the middle estimate is 1.1-fold (0.02 log units) above the measured one; measured number inside the range.
By their numbers in this assay, from the lowest: compound 1; then compounds 4, 2 and 3 (each within the scatter of the next).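

In this assay, the but-3-en-1-yl chain of compound 4 brings a double bond to this position, and neither a 1.1-fold lower number from compound 3 to compound 4 (0.05 log units; within the scatter) nor a 1.1-fold lower number from compound 2 to compound 4 (0.04 log units; within the scatter) lies beyond the scatter, so saturated, double-bonded and triple-bonded hydrocarbon chains are not told apart here. The isopropoxy-bearing chain stays separate from this third hydrocarbon chain as well, with a 2.1-fold higher number from compound 1 to compound 4 (0.32 log units; beyond the scatter) in the modest range. No measured information is available to explain these results.

The compounds shown leave open whether an amine, a carboxylic acid or a longer hydrocarbon chain at this position would move the number away from the values of compounds 2, 3 and 4. They also leave open whether the lower number of compound 1 follows the oxygen or the branching of isopropoxy, which methoxy or isobutyl in its place could separate.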